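A few compounds are considered here, and "the series" means these few. Any claim that something is new, unique, unknown or untested is made for them only; others in the source may bear on it.

Compound 1 `C#Cc1cccc(NC(=O)CCc2cccc3c2B(O)OC3)c1` gives the lower of the two numbers recorded so far in a functional assay on SK-OV-3 cells (Homo sapiens) for antiproliferative activity, read by MTT assay, with a stated time of 72 h (a higher number here means a weaker inhibitor, a lower number a stronger inhibitor), at 980 nM. Compound 2 `O=C(CCc1cccc2c1B(O)OC2)Nc1ccc(-c2ccccc2)cc1` gives 48000 nM in this assay, a gap well beyond the scatter. Compound 3 `O=C(CCc1cccc2c1B(O)OC2)Nc1cccc(-c2ccc(Cl)cc2)c1` differs from compound 1 in one place: 4-chlorophenyl in place of ethynyl on an aromatic carbon. Among the measured compounds shown here, no measured pair shows this exact change, so its effect is uncertain, but since compound 2 gives 48000 nM the step from compound 1 to compound 3 is expected to raise the number, a 5.1-fold higher number from compound 1 to compound 3 (0.71 log units; beyond the scatter). Compound 3 is therefore estimated at 5000 nM, with a range of 1500 nM to 20000 nM.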

Compound 3, half-maximal inhibitory concentration: 220 nM
For compound 3 the middle estimate is 23-fold (1.36 log units) above the measured one; the measured number lies below the stated range.
By their numbers in this assay, from the lowest: compound 3; then compound 1; then compound 2.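

Putting the much larger 4-chlorophenyl in place of ethynyl on this aromatic carbon gives a 4.5-fold lower number from compound 1 to compound 3 (0.65 log units; beyond the scatter) in this assay and so shows that the number can fall as the group grows. This place, meta to a large group, accepts an added six-membered aromatic ring with no loss in this one case. Nothing at hand gives a reason for the gain.

On these data alone, what a plain phenyl would give here remains open, as does the role of the chlorine. An amine or a carboxylic acid in its place on the ring is also untested among the compounds shown.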